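Piperazin-1-yl in Place of Piperidin-1-yl

This account rests on a few compounds, and the source may have more. Where it says the series, first, only, none or still open, it means among the compounds named here.

In a functional assay on U-251 cells (Homo sapiens) for inhibition, read by sulforhodamine B assay, with a stated time of 72 h (a lower number here means that less compound is needed, a higher number that more compound is needed for the effect), compound 1 `O=C(/C=C/c1ccc([N+](=O)[O-])o1)c1ccc(I)cc1` gives 12500 nM. Compound 2 `O=C(/C=C/c1ccc([N+](=O)[O-])o1)c1ccc(N2CCCCC2)cc1` gives only a limit, > 50000 nM. Going by the values given here, the one measured step at this place is an at least 4.0-fold higher number from compound 1 to compound 2 (0.60 log units; beyond the scatter). Compound 3 `O=C(/C=C/c1ccc([N+](=O)[O-])o1)c1ccc(N2CCNCC2)cc1` changes that same group again: piperazin-1-yl in place of piperidin-1-yl on an aromatic carbon. Among the compounds with values here, no measured step covers this exchange of one ring for another, and the size of the earlier step says little about it. Any step in this assay is therefore expected to stay within the scatter. The estimated step is an at least 1.2-fold lower number from compound 2 to compound 3 (0.09 log units; that floor lies within the scatter). For compound 3 the expected value is 40000 nM, with an estimated range from 12000 nM to 60000 nM.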

Compound 3, half-maximal effective concentration: 16700 nM
Compound 3: the middle estimate sits 2.4-fold (0.38 log units) above what was measured; low and high end bracket the measured number.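

In this assay the exchange of one ring carbon for a nitrogen gives an at least 2.9-fold lower number from compound 2 to compound 3 (0.47 log units; beyond the scatter) and so shows that this position does not treat the two six-membered rings alike. Set against iodo, piperazin-1-yl gives a 1.3-fold higher number from compound 1 to compound 3 (0.13 log units; within the scatter) and so shows that a ring at this place does not by itself raise the number. On these data alone, the true size of the step from compound 2 stays unknown, since compound 2 holds only a limit: the limit of > 50000 nM in this assay, at which 1 of the 3 values shown sits.

Open, as far as these compounds go, is how a morpholin-4-yl or 4-methylpiperazin-1-yl group at this place would compare.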